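Swapping a hydroxyquinoline for an indolylmethyl group

The source may hold more compounds than are shown below. What is called first, only, known or untested is meant among the compounds shown, and "the series" means these compounds.

compound 1 `Cn1c(=O)c(S(=O)(=O)c2ccc(F)cc2F)cc2cnc(Nc3cccc4[nH]ccc34)nc21` (750 nM)
compound 2 `Cn1ccc2cc(Nc3ncc4cc(S(=O)(=O)c5ccc(F)cc5F)c(=O)n(C)c4n3)ccc21` (750 nM)
compound 3 `Cn1c(=O)c(S(=O)(=O)c2ccc(F)cc2F)cc2cnc(Nc3ccc4cccc(O)c4n3)nc21` (5000 nM)

All three values come from a functional assay on DU-145 cells (Homo sapiens) for inhibition, read by trypan blue exclusion, with a stated time of 72 h (on this read-out lower numbers stand for stronger inhibition and higher numbers for weaker inhibition), and share one core. Among them, compound 3 (5000 nM) has the highest number, so it is the weakest of the three. Compound 4 `Cn1c(=O)c(S(=O)(=O)c2ccc(F)cc2F)cc2cnc(NCc3ccc4[nH]ccc4c3)nc21` differs from compound 3 on a nitrogen on an aromatic ring: (1H-indol-5-yl)methyl stands in place of 8-hydroxyquinolin-2-yl ((1H-indol-5-yl)methyl in place of 8-hydroxyquinolin-2-yl on a nitrogen on an aromatic ring).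

Within the data shown here, three measured steps bear on this change. Two of them lead to the 8-hydroxyquinolin-2-yl group and raise the number: a 6.7-fold higher number from compound 1 to compound 3 (0.82 log units; beyond the scatter) and a 6.7-fold higher number from compound 2 to compound 3 (0.82 log units; beyond the scatter). The third, no change at the digits printed from compound 1 to compound 2 (within the scatter), shows that these two indole-bearing groups gave matching values. Among the measured compounds shown here, no measured compound carries (1H-indol-5-yl)methyl, so its link to the nitrogen remains untested, and only part of the gap is expected to close. In this assay the expected step is a 3.3-fold lower number from compound 3 to compound 4 (0.52 log units; beyond the scatter) and points toward stronger inhibition. Compound 4 is estimated at 1500 nM (expected range 500 nM to 5000 nM).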

Compound 4, half-maximal inhibitory concentration: 100000 nM
For compound 4 the middle estimate is 67-fold (1.82 log units) below the measured one; measured number outside the range, above it.
By their numbers in this assay, from the lowest: compounds 1 and 2 (each within the scatter of the next); then compound 3; then compound 4.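

In this assay, among these compounds, this position proves far less tolerant than the earlier compounds suggested, with a 20-fold higher number from compound 3 to compound 4 (1.30 log units; beyond the scatter) and, measured against the two directly attached indole groups, a 130-fold higher number from compound 2 to compound 4 (2.12 log units; beyond the scatter) and a 130-fold higher number from compound 1 to compound 4 (2.12 log units; beyond the scatter) as well. An indole ring alone is therefore not enough here: compound 4 keeps one, yet it gives the highest number of the four, and among these compounds only it joins its ring system to the nitrogen through a methyl link. Nothing given here explains this loss of inhibition.

The compounds shown leave open whether the methyl link itself accounts for the loss or whether the way the indole is attached also contributes. A (1-methyl-1H-indol-5-yl)methyl group or a plain benzyl group on this nitrogen would help separate those two readings.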